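Replacing the ring substituent of compound 2

The compounds below may be only part of what the source reports. "The series", "measured", "known", "first", "only" and "open" are said of these compounds alone.

In an ADME assay on microsomes from liver (Mus musculus) for metabolic stability, read by LC-MS, using NADPH, with stated times of 15 min and 60 min, tested at 4.6 uM (on this read-out higher numbers stand for a longer-lived compound and lower numbers for a shorter-lived compound), compound 1 (`CC(C)N1CCC(c2ccc3c(c2)oc(=O)n3C(=O)NCCCCc2ccccc2)CC1`) gives 1 h and compound 2 (`CC(C)CN1CCC(c2ccc3c(c2)oc(=O)n3C(=O)NCCCCc2ccccc2)CC1`) gives 1 h, so compound 2 stands level with compound 1. Within the data shown here, the one measured step, no change at the digits printed from compound 1 to compound 2 (within the scatter), is the exchange of isopropyl for isobutyl on an amine nitrogen in a ring. Compound 3 (`CN1CCN(c2ccc3c(c2)oc(=O)n3C(=O)NCCCCc2ccccc2)CC1`) instead carries 4-methylpiperazin-1-yl in place of 1-isobutylpiperidin-4-yl on an aromatic carbon. This change replaces the whole group, whereas the measured step altered only the substituent on its nitrogen, so that step bears on it only weakly. Among the measured compounds shown here, no measured step shows a direction for such an exchange. No shift beyond the usual scatter is expected in this assay, and the estimated step is a 1.3-fold lower number from compound 2 to compound 3 (0.10 log units; within the scatter). For compound 3 the expected half-life is 0.8 h, with an estimated range from 0.3 h to 2 h.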

Compound 3, half-life: < 0.0834 h
Compound 3: a limit, no number; the forecaster's own chance of this, stated with the estimate: 10%; middle value at least 9.5-fold (0.98 log units) from the limit.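

In this assay, replacing the whole group on the aromatic carbon has a large effect, giving an at least 11-fold lower number from compound 2 to compound 3 (1.07 log units; beyond the scatter) and also an at least 11-fold lower number from compound 1 to compound 3 (1.07 log units; beyond the scatter). For compound 3 the read-out is a limit of the assay and not a number: the limit of < 0.0834 h in this assay, at which 1 of the 3 values shown sits. This place on the core is therefore far more sensitive to an exchange of the whole group than the earlier change on the ring nitrogen suggested, which gave no change at the digits printed from compound 1 to compound 2 (within the scatter).

The exchange alters the ring and its nitrogen substituent together, so the compounds shown cannot say which part of 4-methylpiperazin-1-yl carries the effect, nor how far the half-life of compound 3 lies under the limit. A 1-methylpiperidin-4-yl or a 4-isobutylpiperazin-1-yl group at this place would separate the two changes.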